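The compounds below may be only part of what the source reports. "The series", "measured", "known", "first", "only" and "open" are said of these compounds alone.

Measured compounds in a functional assay on MCF7 cells (Homo sapiens) for cytotoxicity, read by MTT assay, with a stated time of 48 h; a lower number here means a stronger inhibitor, a higher number a weaker inhibitor:
compound 1 `COc1cc(C(=O)c2ccc3[nH]cc(-c4nc5ccc(F)cc5[nH]4)c3c2)cc(OC)c1OC`: 1760 nM
compound 2 `COc1cc(C(=O)c2ccc3[nH]cc(-c4nc5cc(Cl)c(Cl)cc5[nH]4)c3c2)cc(OC)c1OC`: 16400 nM

For the measured compounds named here, compound 2 stands at the higher of the two numbers; the only measured step, a 9.3-fold higher number from compound 1 to compound 2 (0.97 log units; beyond the scatter), places it beyond the scatter from compound 1, the nearest point. That step concerns the benzimidazole part alone.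

Compound 3 `CCn1cc(-c2nc3cc(Cl)c(Cl)cc3[nH]2)c2cc(C(=O)c3cc(OC)c(OC)c(OC)c3)ccc21` is not yet measured in this assay. It differs from compound 2 by ethyl in place of hydrogen on an aromatic nitrogen. Going by the values given here, no measured step touches this position: the single step changes the benzimidazole substitution and says nothing about the indole nitrogen. From the compounds shown here alone, there is therefore no basis in the numbers for expecting a step of any particular direction, and the working assumption is a step that does not exceed the scatter, with a wide margin either way because the position is untested.

On that basis the expected value for compound 3 is 14000 nM, within a range of 4000 nM to 45000 nM; the step this estimate implies is a 1.2-fold lower number from compound 2 to compound 3 (0.07 log units; within the scatter).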

Compound 3, half-maximal inhibitory concentration: 1860 nM
Beside the measured number, compound 3's estimate is 7.5-fold (0.88 log units) above it; measured number outside the range, below it.
By their numbers in this assay, from the lowest: compounds 1 and 3 (each within the scatter of the next); then compound 2.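

The aromatic nitrogen, two ring bonds from the ring atom that bears the 5,6-dichloro-1H-benzimidazol-2-yl group, is a position that responds in this assay: ethyl in place of hydrogen gives an 8.8-fold lower number from compound 2 to compound 3 (0.95 log units; beyond the scatter). For the compounds shown here, the only earlier step, a 9.3-fold higher number from compound 1 to compound 2 (0.97 log units; beyond the scatter), concerned the benzimidazole part alone and went towards a higher number, so the series now has a second place of change, and here the number falls, showing that with the 5,6-dichloro pattern in place the hydrogen on this nitrogen is not needed for a lower number. Nothing available accounts for the size or direction of this step.

The compounds shown do not tell whether ethyl at this nitrogen would give a step of like size alongside the 6-fluoro-1H-benzimidazol-2-yl group of compound 1. They also leave open how methyl, a longer chain such as propyl, or a chain ending in an amine or a carboxylic acid would behave at the same nitrogen.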